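This account rests on a few compounds, and the source may have more. Where it says the series, first, only, none or still open, it means among the compounds named here.

Going by the values given here, compound 2 `CCCCOC(=O)N1CCCc2cc(S(=O)(=O)N3CC(c4ccccc4)NC3=O)ccc21` holds the only number in a functional assay on K562 cells (Homo sapiens) for antiproliferative activity, read by MTT assay (a lower number here means a stronger inhibitor, a higher number a weaker inhibitor), where compound 2 gives 3680 nM. Compound 1 `CCOC(=O)N1CCCc2cc(S(=O)(=O)N3CC(c4ccccc4)NC3=O)ccc21` sits at a limit of this assay, > 20000 nM, so only the limit of > 20000 nM in this assay, at which 1 of the 2 values shown sits, is known of it. Compound 3 `NC(=O)N1CCCc2cc(S(=O)(=O)N3CC(c4ccccc4)NC3=O)ccc21` differs from compound 2 by amino in place of butoxy on a carbonyl carbon. Among the compounds with values here, the one measured step bearing on this, an at least 5.4-fold lower number from compound 1 to compound 2 (0.73 log units; beyond the scatter), favoured the longer chain; compound 3 drops the chain entirely, so the reverse is expected, a 4.1-fold higher number from compound 2 to compound 3 (0.61 log units; beyond the scatter). Compound 3 is therefore estimated at 15000 nM, between 5000 nM and 50000 nM, with a real chance that this assay returns only a limit.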

Compound 3, half-maximal inhibitory concentration: 3660 nM
Compound 3: middle estimate off by 4.1-fold (0.61 log units), on the high side; the whole stated range lies above it.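

In this assay amino in place of butoxy on the carbonyl carbon separates nothing (a 1.0-fold lower number from compound 2 to compound 3 (0.00 log units; within the scatter)). The butoxy chain is therefore not needed for this level of activity, and chain length alone does not order the series: amino, with no chain at all, matches butoxy. Compound 1 is a limit of the assay, so its gap to the amino compound is only a bound (an at least 5.4-fold lower number from compound 1 to compound 3 (0.73 log units; beyond the scatter)).

Open, from the compounds shown here alone, is whether a butylamino group on the same carbonyl carbon, or a longer chain such as hexyloxy, moves the number beyond the scatter.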